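Second fluoro on the piperazine aryl of compound 3

The source may hold more compounds than are shown below. What is called first, only, known or untested is meant among the compounds shown, and "the series" means these compounds.

Of the compounds shown here, three sharing one core have been measured in a functional assay on CHO cells with adenosine receptor A1 (Homo sapiens) as the target, read by cAMP accumulation and immunoassay, with a stated time of 6 min, tested at 0.1 uM; a higher number here means a weaker effect of the compound at the concentration tested, a lower number a stronger effect. Compound 1 `Nc1scc(CN2CCN(c3ccc(Cl)c(C(F)(F)F)c3)CC2)c1C(=O)c1ccc(Cl)cc1` gives -12%, compound 2 `Nc1scc(CN2CCN(c3cccnc3)CC2)c1C(=O)c1ccc(Cl)cc1` gives 3.4%, and compound 3 `Nc1scc(CN2CCN(c3cccc(F)c3)CC2)c1C(=O)c1ccc(Cl)cc1` gives -37%. Compound 3 thus stands lowest, with the strongest effect at this concentration: a number 25 percentage points lower from compound 1 to compound 3 (beyond the scatter) and a number 40.4 percentage points lower from compound 2 to compound 3 (beyond the scatter) both lie beyond the scatter, as does a number 15.4 percentage points higher from compound 1 to compound 2 (beyond the scatter).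

Compound 4 `Nc1scc(CN2CCN(c3cc(F)cc(F)c3)CC2)c1C(=O)c1ccc(Cl)cc1` differs from compound 3 in one place: fluoro in place of hydrogen on an aromatic carbon. Going by the values given here, no measured step bears directly on adding a fluoro to a ring that already carries one; the steps seen so far exchange the whole aryl group on the ring nitrogen, and they shifted this assay by modest to large amounts. A single added fluoro is a smaller change, so the expected step of a number 2 percentage points higher from compound 3 to compound 4 (within the scatter) is small and of uncertain direction, likely within the scatter. Compound 4 is therefore estimated at -35%, within a range from -60% to -5% in this assay .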

Compound 4, a percentage reported as activity, at one concentration (the size of the read-out at that concentration, not a potency): -5%
Compound 4: middle estimate off by 30 percentage points, on the low side, within the range that was stated.
By their numbers in this assay, from the lowest: compound 3; then compounds 1, 4 and 2 (each within the scatter of the next, the first and the last beyond it).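

Adding one fluoro to the ring of compound 3, on an aromatic carbon meta to a fluoro group, is enough to move the result in this assay: the step is a number 32 percentage points higher from compound 3 to compound 4 (beyond the scatter), so a change of a single heavy atom can matter here as much as exchanging a whole aryl group. Going by these compounds alone, the 3,5-difluorophenyl group also brings compound 4 level with both other aryl variants, with a number 8.4 percentage points lower from compound 2 to compound 4 (within the scatter) and a number 7 percentage points higher from compound 1 to compound 4 (within the scatter), which leaves compound 3 alone as the one compound clear of the other three. Nothing available explains why this added fluoro has so large an effect.

As far as these compounds go, it remains open whether the step is specific to fluoro or would also follow from a chloro, a methyl or a methoxy on the same carbon. A single concentration also leaves open how these compounds compare across a range of concentrations.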